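The source may report more compounds than this note shows. Statements on the series, on what has been measured and on what is new or still open speak of the compounds shown alone.

Among the measured compounds shown here, in a functional assay on SMMC-7721 cells (Homo sapiens) for antiproliferative activity, read by CCK-8 assay, with a stated time of 72 h (on this read-out lower numbers stand for stronger inhibition and higher numbers for weaker inhibition), compound 1 `CCc1ccc(SCc2ccc(/C=C/C(=O)Nc3ccccc3N)cc2)cc1` gives "not determined" (no result reported) as its entry, while compound 2 `Nc1ccccc1NC(=O)c1ccc(CSc2cccc(F)c2)cc1` gives 3280 nM as the only number in hand, so it has nothing to be ranked against. Compound 3 `Cc1cc(C)cc(SCc2ccc(C(=O)Nc3ccccc3N)cc2)c1` carries 3,5-dimethylphenyl in place of 3-fluorophenyl on a sulfur and keeps the rest of compound 2. For the measured compounds named here, no measured pair shows what this swap does, so the estimated step of a 1.1-fold lower number from compound 2 to compound 3 (0.04 log units; within the scatter) in this assay is expected to stay within the usual scatter, with no clear direction. For compound 3 the estimated value is 3000 nM with an expected range from 1000 nM to 9000 nM in repeat measurements.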

Compound 3, half-maximal inhibitory concentration: 2760 nM
Estimate against measurement, compound 3: 1.1-fold (0.04 log units) above; the range from low to high includes it.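

In this assay the change to 3,5-dimethylphenyl in place of 3-fluorophenyl on a sulfur gives a 1.2-fold lower number from compound 2 to compound 3 (0.07 log units; within the scatter) and so separates these two groups at this position no more than repeat measurements would. Among the compounds shown here, this is the first measured pair at this position, and it shows that a ring with two methyl groups and a ring with one fluorine can be exchanged here without a clear shift. No measured evidence bears on this result. Going by these compounds, whether an amine or a carboxylic acid on this ring would shift the number beyond the scatter stays open.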